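The source may hold more compounds than are shown below. What is called first, only, known or untested is meant among the compounds shown, and "the series" means these compounds.

Measured compounds in a functional assay on CHO cells for antagonist activity at Orexin/Hypocretin receptor type 1 (Homo sapiens), read by FLIPR and calcium flux; a higher number here means a weaker inhibitor, a lower number a stronger inhibitor:

Compound 1, `CCc1nc(Cl)c2n1CCN([C@@H](C(=O)NC)c1ccccc1)[C@H]2CCc1cccc(C(F)(F)F)c1`, gives 72 nM.
Compound 2, `CCc1nc(Cl)c2n1CCN([C@@H](C(=O)NC)c1ccccc1)[C@H]2COc1ccc(C(F)(F)F)cc1`, gives 431 nM.
Compound 3, `CCc1nc(Cl)c2n1CCN([C@@H](C(=O)NC)c1ccccc1)[C@H]2CCc1ccc(C(F)(F)F)c(Cl)c1`, gives 20 nM.

Compound 3 holds the lowest number of the three in this assay, with compound 1 nearest and compound 2 furthest; both of its steps to the others are beyond the scatter, so it is the strongest inhibitor among the measured set. The step of a 3.6-fold lower number from compound 1 to compound 3 (0.56 log units; beyond the scatter) shows that changing the substitution on the aryl ring at the end of the two-carbon chain moved the number by a modest margin. The step of a 6.0-fold higher number from compound 1 to compound 2 (0.78 log units; beyond the scatter) and the step of a 22-fold lower number from compound 2 to compound 3 (1.33 log units; beyond the scatter) involve a change of linker as well and bear less directly on the present question.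

Compound 4 is `CCc1nc(Cl)c2n1CCN([C@@H](C(=O)NC)c1ccccc1)[C@H]2CCc1ccc(C(F)(F)F)c(F)c1F`. It differs from compound 3 by 2,3-difluoro-4-(trifluoromethyl)phenyl in place of 3-chloro-4-(trifluoromethyl)phenyl on a saturated chain carbon, two bonds along the chain from a saturated ring carbon. For the measured compounds named here, the one comparable step, from compound 1 to compound 3, was modest, and no measured pair shows a fluorine change on this ring. The ring still carries the trifluoromethyl group, so only a small step is expected in this assay, plausibly toward a somewhat higher number, within or just beyond the scatter, as a 1.8-fold higher number from compound 3 to compound 4 (0.24 log units; within the scatter). Compound 4 is therefore estimated at 35 nM in this assay, within a range of 12 nM to 100 nM.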

Compound 4, half-maximal inhibitory concentration: 17 nM
Estimate against measurement, compound 4: 2.1-fold (0.31 log units) above; low and high end bracket the measured number.
By their numbers in this assay, from the lowest: compounds 4 and 3 (each within the scatter of the next); then compound 1; then compound 2.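

In this assay, 2,3-difluoro-4-(trifluoromethyl)phenyl in place of 3-chloro-4-(trifluoromethyl)phenyl on a saturated chain carbon, two bonds along the chain from a saturated ring carbon, gives a 1.2-fold lower number from compound 3 to compound 4 (0.07 log units; within the scatter) and so leaves the number effectively unchanged: at this place, the chlorine of the earlier ring is not needed to reach this level, and two fluorines serve equally well in this read-out. The same ring in place of 3-(trifluoromethyl)phenyl gives a 4.2-fold lower number from compound 1 to compound 4 (0.63 log units; beyond the scatter), which, beside a 3.6-fold lower number from compound 1 to compound 3 (0.56 log units; beyond the scatter), shows that two differently halogenated rings both stand apart from the ring of compound 1, though neither step separates the halogens from the different placing of the trifluoromethyl group. No measurement on hand accounts for either step.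

As far as these compounds go, whether the halogens contribute at all remains open, as a 4-(trifluoromethyl)phenyl ring carrying no chlorine or fluorine would be needed to settle that. Also open, from the compounds shown here alone, is whether the trifluoromethyl group itself can give way at this place, for example to a nitrile, a methoxy group or a carboxylic acid, while the number stays at the level of these two compounds.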